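Chloro for hydrogen on two related cores, tested for cytotoxicity

This account rests on a few compounds, and the source may have more. Where it says the series, first, only, none or still open, it means among the compounds named here.

The series holds four compounds. Compound 1 `O=c1[nH]nc2n(c1=O)CCN2c1ccccc1` and compound 3 `O=c1[nH]nc2n(c1=O)CCN2c1ccc(Cl)cc1` share one core; compound 2 `N=c1c(=O)[nH]nc2n1CCN2c1ccccc1` and compound 4 `N=c1c(=O)[nH]nc2n1CCN2c1ccc(Cl)cc1` share another. How the core of compound 2 differs from the core of compound 1 is not broken down here.

In an ADME assay on Vero cells (Chlorocebus sabaeus) for cytotoxicity, with a stated time of 72 h, tested at 10 ug/mL (a higher number here means a stronger effect of the compound at the concentration tested, a lower number a weaker effect), compound 1 gives 7%, and compound 3 gives 0%. Between them stands one change chloro in place of hydrogen on an aromatic carbon and the step is a number 7 percentage points lower from compound 1 to compound 3 (within the scatter). Compound 2 gives 26% in this assay, the highest of the three numbers, standing beyond the scatter above both compound 1 and compound 3.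

Compound 4 is not yet measured in this assay. It differs from compound 2 by chloro in place of hydrogen on an aromatic carbon, the same change that leads from compound 1 to compound 3, the place being described in the same words for both pairs; the change occurs twice among the compounds shown.

Going by the values given here, the step from compound 2 to compound 4 is expected to be a number 6 percentage points lower from compound 2 to compound 4 (within the scatter), which rests on the single earlier step of a number 7 percentage points lower from compound 1 to compound 3 (within the scatter) lying within the scatter. Because compound 2 gives 26%, compound 4 is expected to give about 20% in this assay. The expected range for compound 4 runs from 5% to 35%, the width reflecting that the earlier step is one observation on a different core.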

Compound 4, a percentage reported as inhibition, at one concentration (the size of the read-out at that concentration, not a potency): 0%
Beside the measured number, compound 4's estimate is 20 percentage points above it; measured number below the stated range.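

In this assay the step for chloro in place of hydrogen on the core of compound 2 is a number 26 percentage points lower from compound 2 to compound 4 (beyond the scatter), so on this core the change goes with a drop in the read-out that exceeds the scatter. Set beside the same change on the core of compound 1, the size of the step does not carry from one core to the other: the same change on two cores in this assay, a number 7 percentage points lower (within the scatter) from compound 1 to compound 3 and a number 26 percentage points lower (beyond the scatter) from compound 2 to compound 4, 19 percentage points apart, beyond the scatter of two such steps The two chloro compounds end at the same printed number, compound 3 at 0% and compound 4 at 0%, so the larger step starts from the higher value of compound 2, but with one pair per core this shows only that the step size differs between these two cores, not why it differs or how the change would behave on any further core.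

Going by these compounds alone, only hydrogen and chloro appear on the six-membered aromatic ring here, so it remains open whether a methoxy group, an amine or a carboxylic acid at the same place would follow the step seen from compound 2 or the one seen from compound 1. Also open, on these data alone, is how these compounds behave at other concentrations, since each read-out is a single-concentration number.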